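The source may hold more compounds than are shown below. What is called first, only, known or untested is meant among the compounds shown, and "the series" means these compounds.

Measured compounds:
compound 1 `COc1cc(OC)c2c(=O)c(OCC(=O)N/N=C/c3sccc3C)c(-c3cc(OC)c(OC)c(OC)c3)oc2c1` — 7740 nM
compound 2 `COc1cc(OC)c2c(=O)c(OCC(=O)N/N=C/c3ccc[nH]3)c(-c3cc(OC)c(OC)c(OC)c3)oc2c1` — 5610 nM
compound 3 `COc1cc(OC)c2c(=O)c(OCC(=O)N/N=C/c3ccco3)c(-c3cc(OC)c(OC)c(OC)c3)oc2c1` — 6050 nM

In a functional assay on MGC-803 cells (Homo sapiens) for cytotoxicity, read by MTT assay, with a stated time of 38 h (a lower number here means a stronger inhibitor, a higher number a weaker inhibitor), compound 3 stands second highest of the three numbers; its nearest neighbour is compound 2 and its furthest compound 1, both within the scatter of it. Compound 4 `COc1cc(OC)c2c(=O)c(OCCCCN3CCN(C)CC3)c(-c3cc(OC)c(OC)c(OC)c3)oc2c1` differs from compound 3 by a group of 10 heavy atoms (8 carbon, 2 nitrogen; one six-membered non-aromatic ring with 2 hetero atoms) in place of a group of 10 heavy atoms (6 carbon, 2 nitrogen, 2 oxygen; one five-membered aromatic ring with 1 hetero atom), on a saturated chain carbon bound to an oxygen on an aromatic ring. For the measured compounds named here, no measured step touches this change: a 1.4-fold lower number from compound 1 to compound 2 (0.14 log units; within the scatter), a 1.3-fold lower number from compound 1 to compound 3 (0.11 log units; within the scatter) and a 1.1-fold higher number from compound 2 to compound 3 (0.03 log units; within the scatter) all swap only the five-membered aromatic ring on the carbon with a double bond to nitrogen, and all fall within the scatter. The new group removes that whole portion, so the measured steps give no direction; the expected step for compound 4 is a 1.2-fold lower number from compound 3 to compound 4 (0.08 log units; within the scatter), not beyond the scatter but with a wide range. Compound 4 is estimated at 5000 nM, between 1200 nM and 20000 nM.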

Compound 4, half-maximal inhibitory concentration: 12200 nM
For compound 4 the middle estimate is 2.4-fold (0.39 log units) below the measured one; the range from low to high includes it.
By their numbers in this assay, from the lowest: compounds 2, 3, 1 and 4 (each within the scatter of the next, the first and the last beyond it).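

In this assay, for the compounds shown here, 3-(4-methylpiperazin-1-yl)propyl on a saturated chain carbon bound to an oxygen on an aromatic ring removes the whole portion carrying the five-membered aromatic ring, and this gives the first change here larger than a ring swap: (a 2.0-fold higher number from compound 3 to compound 4 (0.30 log units; within the scatter)), (a 1.6-fold higher number from compound 1 to compound 4 (0.20 log units; within the scatter)) and (a 2.2-fold higher number from compound 2 to compound 4 (0.34 log units; beyond the scatter)). Only the last step passes the scatter, so compound 4 separates modestly from compound 2 alone. Nothing on hand accounts for these steps.
Open, on these data alone, is whether a morpholine or a dimethylamino group on the same chain, or a longer chain carrying the methylpiperazine, would shift the number.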